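The source may report more compounds than this note shows. Statements on the series, on what has been measured and on what is new or still open speak of the compounds shown alone.

Measured so far in the series:

compound 1 `CCn1c(SCC(=O)c2ccccc2)nnc1-c1ccc(OC)cc1` — 60%
compound 2 `COc1ccc(-c2nnc(SCC(=O)c3ccccc3)n2-c2ccccc2)cc1OC` — 57%
compound 3 `COc1ccc(-c2nnc(SC/C(=N/O)c3ccccc3)n2-c2ccccc2)cc1OC` — 61%

In a functional assay on the whole organism (strain albino) for inhibition, with Rattus norvegicus as the target, read by paw edema, with a stated time of 2 h, at a dose of 0.28 mmol/kg by the oral route (on this read-out higher numbers stand for more inhibition at the one dose given (going by the name of the read-out) and lower numbers for less inhibition), compound 2 holds the lowest of the three numbers, yet compound 1 and compound 3 both lie within the scatter of it, so no order among the three can be read. The only single-place step shown, a number 4 percentage points higher from compound 2 to compound 3 (within the scatter), concerns an exchange on a saturated chain carbon bound to a sulfur and is itself within the scatter; it does not touch the part of the molecule changed here. Compound 1 differs from compound 2 at more than one place, so only the two values themselves can be set side by side, and they agree within the scatter.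

Compound 4 `COc1ccc(-c2nnc(SCC(=O)c3ccccc3)n2-c2ccccc2)cc1` differs from compound 2 by hydrogen in place of methoxy on an aromatic carbon — the same difference, cut one bond further out, reads 3,4-dimethoxyphenyl to 4-methoxyphenyl. Among the measured compounds shown here, no measured step isolates this change, so there is no basis for expecting movement beyond the scatter. For compound 4 the expected step is a number 1 percentage points higher from compound 2 to compound 4 (within the scatter). Compound 4 is therefore estimated at 58%, with a range from 45% to 70%.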

Compound 4, a percentage reported as inhibition, in the whole organism at one dose (the size of the read-out at that dose, not a potency): 57%
Beside the measured number, compound 4's estimate is 1 percentage points above it, within the range that was stated.
By their numbers in this assay, from the lowest: compounds 2, 4, 1 and 3 (each within the scatter of the next).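

In this assay, among the compounds shown here, hydrogen in place of methoxy on this aromatic carbon, ortho to a methoxy group, reads as no change at the digits printed from compound 2 to compound 4 (within the scatter) and so gives the first direct look at this change: 3,4-dimethoxyphenyl and 4-methoxyphenyl are not told apart at this one dose. Phenyl in place of ethyl on the aromatic nitrogen reads as a number 3 percentage points lower from compound 1 to compound 4 (within the scatter) and adds a second single-place comparison that also stays within the scatter, so neither place shows an effect on this read-out. No supporting data bear on these two results.

As far as these compounds go, whether an amine or a carboxylic acid on this aromatic carbon would move the number beyond the scatter remains open. So does whether a longer chain on the aromatic nitrogen would do so, and whether either change would show at another dose or time.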